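Swapping the aryl group on the piperazine: compound 4

The source may hold more compounds than are shown below. What is called first, only, known or untested is meant among the compounds shown, and "the series" means these compounds.

Measured so far:
compound 1 `CC1(c2ccc(F)cc2)NC(=O)N(CC(O)CN2CCN(c3ccccc3)CC2)C1=O` gives 223 nM
compound 2 `CCOc1ccccc1N1CCN(CC(O)CN2C(=O)NC(C)(c3ccc(F)cc3)C2=O)CC1` gives 10 nM
compound 3 `CC1(c2ccc(F)cc2)NC(=O)N(CC(O)CN2CCN(c3ccc(Cl)cc3)CC2)C1=O` gives 908 nM

All three were tested in an assay on HEK293 cells for displacement of a labelled ligand from 5-hydroxytryptamine receptor 7 (Homo sapiens); on this read-out lower numbers stand for stronger inhibition and higher numbers for weaker inhibition. Compound 2 stands lowest of the three numbers, with compound 1 nearest and compound 3 furthest. The step of a 22-fold lower number from compound 1 to compound 2 (1.35 log units; beyond the scatter) is large, while a 4.1-fold higher number from compound 1 to compound 3 (0.61 log units; beyond the scatter) is modest in the opposite direction, and a 91-fold higher number from compound 2 to compound 3 (1.96 log units; beyond the scatter) is the largest gap seen.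

Compound 4 `CC1(c2ccc(F)cc2)NC(=O)N(CC(O)CN2CCN(c3ccc(Cl)c(Cl)c3)CC2)C1=O` has not yet been measured. It differs from compound 2 in one place: 3,4-dichlorophenyl in place of 2-ethoxyphenyl on an amine nitrogen in a ring. The step that bears most directly on this change is a 91-fold higher number from compound 2 to compound 3 (1.96 log units; beyond the scatter), where the same 2-ethoxyphenyl was also lost and a chlorophenyl was brought in, giving a sharp loss of potency. The smaller step of a 4.1-fold higher number from compound 1 to compound 3 (0.61 log units; beyond the scatter) points the same way. On this basis a large rise in the number is expected for compound 4, roughly a 150-fold higher number from compound 2 to compound 4 (2.18 log units; beyond the scatter). Compound 4 is therefore estimated at 1500 nM in this assay, with a plausible range from 400 nM to 6000 nM.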

Compound 4, inhibition constant: 141 nM
Compound 4: the middle estimate sits 11-fold (1.03 log units) above what was measured, outside the stated range (below it).
By their numbers in this assay, from the lowest: compound 2; then compounds 4 and 1 (each within the scatter of the next); then compound 3.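

In this assay, a chloro group does not always push the number up: a 4.1-fold higher number from compound 1 to compound 3 (0.61 log units; beyond the scatter) is followed by a 6.4-fold lower number from compound 3 to compound 4 (0.81 log units; beyond the scatter) when one further chloro turns 4-chlorophenyl into 3,4-dichlorophenyl. The effect of a chloro on this aryl ring therefore depends on what else the ring carries, and with both chloro groups in place the result is a 1.6-fold lower number from compound 1 to compound 4 (0.20 log units; within the scatter), so 3,4-dichlorophenyl and plain phenyl cannot be told apart here. Leaving 2-ethoxyphenyl still costs a great deal, with a 14-fold higher number from compound 2 to compound 4 (1.15 log units; beyond the scatter), though much less than a 91-fold higher number from compound 2 to compound 3 (1.96 log units; beyond the scatter) seen with 4-chlorophenyl, and 2-ethoxyphenyl remains the aryl group with the lowest number among these four compounds.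

No measurement offered here explains why the further chloro restores potency or why 2-ethoxyphenyl does so much better. As far as these compounds go, it also remains open whether the benefit of 2-ethoxyphenyl belongs to the ethoxy group itself, and how a smaller methoxy group, or a trifluoromethyl group, on the aryl ring would compare with these four compounds.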